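Rearranging one amide without changing its atoms

This account rests on a few compounds, and the source may have more. Where it says the series, first, only, none or still open, it means among the compounds named here.

Measured in a functional assay on Huh-5-2 cells (Homo sapiens), read by MTT assay; a higher number here means that more compound is tolerated, a lower number that less compound is tolerated:
Compound 1 `CC(=O)Nc1ccc(-c2ccc(Cl)cc2)c(COc2ccc(-c3nc4cc(C(=O)O)ccc4n3C3CCCCC3)c(F)c2)c1`: 24000 nM
Compound 2 `CC(C)C(=O)N(C)c1ccc(-c2ccc(Cl)cc2)c(COc2ccc(-c3nc4cc(C(=O)O)ccc4n3C3CCCCC3)c(F)c2)c1`: 22000 nM

In this assay, going by the values given here, compound 2 at 22000 nM stands within the scatter of compound 1, the only other measured compound. Compound 3 `CC(=O)N(c1ccc(-c2ccc(Cl)cc2)c(COc2ccc(-c3nc4cc(C(=O)O)ccc4n3C3CCCCC3)c(F)c2)c1)C(C)C` has the same atoms as compound 2, joined differently: acetyl(isopropyl)amino in place of (isopropylcarbonyl)(methyl)amino on an aromatic carbon. Acetyl(isopropyl)amino replaces (isopropylcarbonyl)(methyl)amino on the aromatic carbon para to a 4-chlorophenyl group.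

Among the compounds with values here, one measured step bears on this change. Within the data shown here, replacing acetamido at that same carbon gave a 1.1-fold lower number from compound 1 to compound 2 (0.04 log units; within the scatter), so the one change measured there stayed within the scatter. Among the measured compounds shown here, no measured compound carries isopropyl on the amide nitrogen, so this evidence is indirect. The expected size is therefore none beyond the scatter, in neither direction, and the estimated step is a 1.0-fold higher number from compound 2 to compound 3 (0.02 log units; within the scatter). For compound 3 the expected value is 23000 nM, within an estimated range of 12000 nM to 40000 nM.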

Compound 3, half-maximal cytotoxic concentration: 20000 nM
Beside the measured number, compound 3's estimate is 1.2-fold (0.06 log units) above it; low and high end bracket the measured number.
By their numbers in this assay, from the lowest: compounds 3, 2 and 1 (each within the scatter of the next).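

In this assay, exchanging the groups on either side of the amide while keeping the same atoms gave a 1.1-fold lower number from compound 2 to compound 3 (0.04 log units; within the scatter), so this rearrangement of acetyl(isopropyl)amino against (isopropylcarbonyl)(methyl)amino on the aromatic carbon para to a 4-chlorophenyl group stayed within the scatter. Isopropyl in place of hydrogen on the amide-type nitrogen, a change the earlier compounds did not include, gave a 1.2-fold lower number from compound 1 to compound 3 (0.08 log units; within the scatter), which also stayed within the scatter. No measurement on hand offers an explanation for these results.

The compounds shown leave open whether an amine, a carboxylic acid or a longer chain on the amide nitrogen at this carbon would also stay within the scatter. Going by these compounds, all three compounds carry an amide there, so what the amide itself contributes also remains open.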